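Removing the chloro from compound 2's aryl ring

The source may report more compounds than this note shows. Statements on the series, on what has been measured and on what is new or still open speak of the compounds shown alone.

Measured so far in a functional assay on cells (Pituitary gland cell) for antagonist activity at Gonadotropin-releasing hormone receptor (Rattus norvegicus); on this read-out lower numbers stand for stronger inhibition and higher numbers for weaker inhibition:
compound 1 `O=[N+]([O-])c1cc2c(OCCC3CCCCN3)c(-c3cccc(Cl)c3)c(O)nc2cc1Cl`: 40 nM
compound 2 `O=[N+]([O-])c1cc2c(OCCC3CCCCN3)c(-c3ccccc3Cl)c(O)nc2cc1Cl`: 360 nM

Within the data shown here, compound 2 gives the higher of the two numbers, with a 9.0-fold higher number from compound 1 to compound 2 (0.95 log units; beyond the scatter) being the one measured step. Compound 3 `O=[N+]([O-])c1cc2c(OCCC3CCCCN3)c(-c3ccccc3)c(O)nc2cc1Cl` differs from compound 2 by hydrogen in place of chloro on an aromatic carbon, placed ortho to a large group. Among the measured compounds shown here, no measured step removes a chloro outright; the one step only moves it, and it was modest. Compound 3 is therefore expected to give a number between those of compound 2 and compound 1, a step of a 2.4-fold lower number from compound 2 to compound 3 (0.38 log units; beyond the scatter), estimated at 150 nM with a range of 40 nM to 500 nM in this assay.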

Compound 3, half-maximal inhibitory concentration: 410 nM
The estimate for compound 3 lay 2.7-fold (0.44 log units) below the measured number; the measured number falls inside the stated range.
By their numbers in this assay, from the lowest: compound 1; then compounds 2 and 3 (each within the scatter of the next).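

In this assay, hydrogen and chloro cannot be told apart at this place, ortho to a large group: the result is a 1.1-fold higher number from compound 2 to compound 3 (0.06 log units; within the scatter). The chloro of compound 1 does matter, with a 10-fold higher number from compound 1 to compound 3 (1.01 log units; beyond the scatter), so among these three compounds only the 3-chlorophenyl group stands apart from phenyl. Nothing available accounts for this difference between the two chloro placements. Going by these compounds, whether a fluoro, methyl or methoxy group in place of the chloro of compound 1 would keep its number remains open.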